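Trading a Benzyl Group for an Ethyl Group

This account rests on a few compounds, and the source may have more. Where it says the series, first, only, none or still open, it means among the compounds named here.

Within the data shown here, in an ADME assay on J774 cells (Mus musculus) for cytotoxicity (on this read-out lower numbers stand for an effect already at smaller amounts and higher numbers for an effect only at larger amounts of compound), compound 2 `COC(=O)c1c[nH]c2ccc(OCc3ccccc3)cc2c1=O` gives 7590 nM as the only true number so far. Compound 1 `COC(=O)c1c[nH]c2cc(OCCOc3ccccc3)c(C)cc2c1=O` stands at > 20000 nM in the same test, and that figure is a limit of the assay, not a number. Compound 2 therefore has no exact value to be compared with.

The next molecule is compound 3 `CCOc1ccc2[nH]cc(C(=O)OC)c(=O)c2c1` and it arises from compound 2 by a single change, methyl in place of phenyl on a saturated chain carbon bound to an oxygen on an aromatic ring in short: methyl in place of phenyl on a saturated chain carbon bound to an oxygen on an aromatic ring, which also reads as benzyl to ethyl.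

Among the measured compounds shown here, no two measured compounds differ in just one place, so no measured step can guide the size of this one. The expected change is a moderate move toward a higher number, an estimated 1.8-fold higher number from compound 2 to compound 3 (0.27 log units; within the scatter) in this assay with real uncertainty. This expectation takes compound 2 at 7590 nM as its anchor. For compound 3 the expected value is 14000 nM within an estimated range of 6000 nM to 32000 nM and a reading at the assay limit remains possible.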

Compound 3, half-maximal effective concentration: > 20000 nM
Compound 3: only a limit was reported; the forecaster's own chance of this, stated with the estimate: 40%; middle value at least 1.4-fold (0.15 log units) away from the limit.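

This is the first pair shown that differs in only one place, and it ties the measurable effect of compound 2 in this assay to the phenyl on a saturated chain carbon bound to an oxygen on an aromatic ring. Changing benzyl to ethyl gives an at least 2.6-fold higher number from compound 2 to compound 3 (0.42 log units; beyond the scatter), so on these cells the effect now appears only at larger amounts of compound. Compound 3 gives > 20000 nM, which is a limit and not a number, so this step marks only the smallest possible change, and its true size stays unknown because the reading stops at the top of the test: the limit of > 20000 nM in this assay, at which 2 of the 3 values shown sit.

On these data alone, it remains open how much of the phenyl is needed, since a longer chain such as propyl or butyl in place of the ethyl, or a benzyl group carrying an amine or a carboxylic acid on its ring, could fall anywhere from the value of compound 2 to the limit. Compound 1 differs from both others in more than one place, so it cannot show whether the same swap would act alike on a differently substituted core.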